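The source may hold more compounds than are shown below. What is called first, only, known or untested is meant among the compounds shown, and "the series" means these compounds.

This account follows the step from compound 1 to compound 4 in a functional assay on HCT-116 cells (Homo sapiens) for antiproliferative activity, read by sulforhodamine B assay, with a stated time of 3 days, tested at 50 uM; on this read-out lower numbers stand for a weaker effect and higher numbers for a stronger effect at the one concentration tested. Compound 1, `O=C(/C=C/c1ccc(F)cc1)c1ccc(OCc2ccccc2)cc1`, stands without a number on this read-out: in this assay compound 1 gives "not determined" (no result reported). The same holds for compound 3, `O=C(/C=C/c1ccc(Cl)cc1)c1ccc(OCc2ccccc2)cc1`, which in this assay gives "not determined" (no result reported). Among the compounds with values here, the only number in the set comes from compound 2, `O=C(/C=C/c1ccc(F)cc1)c1ccccc1`, which in this assay gives 100%, a result at the top of the scale. Compound 4, `Cc1ccc(COc2ccc(C(=O)/C=C/c3ccc(F)cc3)cc2)cc1`, differs from compound 1 in a single place: methyl in place of hydrogen on an aromatic carbon. Within the data shown here, no step between measured compounds describes such a change, so nothing in the data tells its size. In this assay the author expects from this change no step beyond the usual scatter, in neither direction. Given the shared core and the high value of compound 2, compound 4 is expected to land near 80%, with a range from 40% to 100%.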

Compound 4, a percentage reported as inhibition, at one concentration (the size of the read-out at that concentration, not a potency): 15.4%
Estimate against measurement, compound 4: 64.6 percentage points above; measured number below the stated range.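

Compound 1 stands without a number in this assay while compound 4 gives 15.4%, so no step can be read between them. The compounds shown leave open what methyl in place of hydrogen does on this read-out. No measured evidence offers an explanation for the result.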